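Sulfoxide to sulfone on the ring-nitrogen substituent

This account rests on a few compounds, and the source may have more. Where it says the series, first, only, none or still open, it means among the compounds named here.

Measured so far:
compound 1 `NS(=O)(=O)NNc1nonc1/C(=N/O)Nc1ccc(F)c(Br)c1` gives 101 nM
compound 2 `[O-][S+]1CC(Nc2nonc2/C(=N/O)Nc2ccc(F)c(Br)c2)C1` gives 79 nM

Both numbers come from an assay on HeLa cells for inhibition of Indoleamine 2,3-dioxygenase 1 (Homo sapiens), read by spectrophotometry, with a stated time of 24 h; on this read-out higher numbers stand for an effect only at larger amounts of compound and lower numbers for an effect already at smaller amounts. Compound 2 sits at the lowest of the two numbers shown, though the step of a 1.3-fold lower number from compound 1 to compound 2 (0.11 log units; within the scatter) is within the scatter, so the two compounds cannot be told apart on this read-out.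

Compound 3 `O=S1(=O)CC(Nc2nonc2/C(=N/O)Nc2ccc(F)c(Br)c2)C1` differs from compound 2 in that (a group of 6 heavy atoms (3 carbon, 2 oxygen, 1 sulfur; one four-membered non-aromatic ring with 1 hetero atom) in place of a group of 5 heavy atoms (3 carbon, 1 oxygen, 1 sulfur; one four-membered non-aromatic ring with 1 hetero atom), on a nitrogen on an aromatic ring). Going by the values given here, the only measured step that touches the same nitrogen is a 1.3-fold lower number from compound 1 to compound 2 (0.11 log units; within the scatter), where a more extensive exchange at that place left the number within the scatter. The change to compound 3 is smaller still, and no step beyond the scatter bears on it. A step of about a 1.1-fold higher number from compound 2 to compound 3 (0.03 log units; within the scatter) is therefore expected, not beyond the scatter in either direction. Compound 3 is estimated at 85 nM, with a range from 40 nM to 180 nM.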

Compound 3, half-maximal effective concentration: 59 nM
Compound 3: middle estimate off by 1.4-fold (0.16 log units), on the high side; low and high end bracket the measured number.
By their numbers in this assay, from the lowest: compounds 3, 2 and 1 (each within the scatter of the next).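

On the nitrogen on an aromatic ring, the added oxygen on the four-membered ring group gives a 1.3-fold lower number from compound 2 to compound 3 (0.13 log units; within the scatter) in this assay, so the sulfoxide and sulfone forms of this group cannot be told apart. The wider exchange of the open-chain group of compound 1 for the sulfone ring group gives a 1.7-fold lower number from compound 1 to compound 3 (0.23 log units; within the scatter), also within the scatter, so none of the three groups at this position can be separated from the others on this read-out. No supporting measurement bears on these results.

On these data alone, whether an amine, a carboxylic acid or a longer alkyl chain on this nitrogen would move the number beyond the scatter stays open. Also open, as far as these compounds go, is whether these three groups would remain within the scatter of one another if chlorine replaced the bromine.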